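Long-chain amide analogues of a bicyclic acid: cytotoxicity outlook

The source may hold more compounds than are shown below. What is called first, only, known or untested is meant among the compounds shown, and "the series" means these compounds.

In an ADME assay on A-431 cells (Homo sapiens) for cytotoxicity, read by MTT assay, with a stated time of 72 h (a lower number here means a stronger inhibitor of growth, a higher number a weaker inhibitor of growth), compound 1 `CCCCNC(=O)C1C(C(=O)O)[C@@H]2CC[C@H]1O2` gives 10000 nM and compound 2 `O=C(O)CCCNC(=O)C1C(C(=O)O)[C@@H]2CC[C@H]1O2` gives 10000 nM; the change between them is methyl in place of carboxy on a saturated chain carbon, three bonds along the chain from an amide-type nitrogen and it produced no change at the digits printed from compound 2 to compound 1 (within the scatter). Compound 3 `O=C(O)CCCCCCCNC(=O)C1C(C(=O)O)[C@@H]2CC[C@H]1O2` gives 10000 nM in this assay, and its core differs from compound 2 by 4-carboxybutyl in place of carboxy on a saturated chain carbon, three bonds along the chain from an amide-type nitrogen, with no change at the digits printed from compound 2 to compound 3 (within the scatter) and, from compound 1, no change at the digits printed from compound 1 to compound 3 (within the scatter). Compound 4 `CCCCCCCCNC(=O)C1C(C(=O)O)[C@@H]2CC[C@H]1O2` has not yet been tested; it differs from compound 3 by methyl in place of carboxy on a saturated chain carbon, seven bonds along the chain from an amide-type nitrogen. This is the same kind of change as that from compound 2 to compound 1, but here the place is seven bonds along the chain from an amide-type nitrogen rather than three. Because compound 2 and compound 1 showed no change at the digits printed from compound 2 to compound 1 (within the scatter), the step is expected to be no change at the digits printed from compound 3 to compound 4 (within the scatter). Compound 4 is therefore estimated at 10000 nM in this assay, with a range from 5000 nM to 20000 nM.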

Compound 4, concentration for 50% growth inhibition: 10000 nM
For compound 4 middle estimate and measured number coincide at the digits printed, within the range that was stated.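

In this assay, putting methyl in place of carboxy at the seventh chain bond gave no change at the digits printed from compound 3 to compound 4 (within the scatter), and the other two comparisons read the same, with no change at the digits printed from compound 2 to compound 4 (within the scatter) and no change at the digits printed from compound 1 to compound 4 (within the scatter). The change from carboxy to methyl thus carried from one core to the other without a difference: the same change on two cores in this assay, no change at the digits printed (within the scatter) from compound 2 to compound 1 and no change at the digits printed (within the scatter) from compound 3 to compound 4, 1.0-fold (0.00 log units) apart, within the scatter of two such steps This shows agreement only between two flat steps among compounds that stand level, and it does not show that the change would carry over on a core where it had a measurable effect.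

The compounds shown leave open whether a longer chain or an amine on the amide nitrogen would alter the reading in this assay. They also leave open what an ester would do in place of the carboxylic acid on the shared core.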